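Cytotoxicity limits and a smaller group on nitrogen

The source may report more compounds than this note shows. Statements on the series, on what has been measured and on what is new or still open speak of the compounds shown alone.

Compound 1 `CCCc1nn(C)c2c(Nc3ccc(C(=O)O)cc3)nc(-c3cc(OC)c(OC)c(OC)c3)nc12`: > 50000 nM
Compound 2 `CCCc1nn(C)c2c(NCC(C)C)nc(/C=C/c3ccccc3)nc12`: > 50000 nM

Both entries are limits of the assay and not numbers. In an ADME assay on RAW264.7 cells (Mus musculus) for cytotoxicity (on this read-out lower numbers stand for stronger inhibition and higher numbers for weaker inhibition), compound 1 gives > 50000 nM as its reading, so it has a limit and no exact position. Compound 2 gives > 50000 nM as its reading, which is also a limit. The measured data therefore offer only the limit of > 50000 nM in this assay, at which 2 of the 2 values shown sit, as a reference point.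

Compound 3 `CCCc1nn(C)c2c(NC(C)C)nc(-c3cc(OC)c(OC)c(OC)c3)nc12` has not yet been measured. It differs from compound 1 as follows: isopropyl in place of 4-carboxyphenyl on a nitrogen on an aromatic ring, which means isopropyl in place of 4-carboxyphenyl on a nitrogen on an aromatic ring. Among the measured compounds shown here, no measured pair shows what such a swap does, so there is no direct guide to its size.

The expectation for this change rests on compound 1 and its > 50000 nM limit, and it is for no shift beyond the scatter in either direction. The estimated change is an at least 1.1-fold lower number from compound 1 to compound 3 (0.04 log units; that floor lies within the scatter) in this comparison. Compound 3 is expected to read about 45000 nM as a middle value, and more likely than not to be reported as a limit. The estimated range for compound 3 runs from 15000 nM to 50000 nM in this assay for now.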

Compound 3, half-maximal inhibitory concentration: > 50000 nM
Compound 3: a limit, no number; the forecaster's own chance of this, stated with the estimate: 70%; at least 1.1-fold (0.04 log units) between middle value and limit.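

In this assay compound 3 gives > 50000 nM, which is a limit of the assay and not a number. Among the compounds shown here, compound 1 also carries a limit, so no step from compound 1 to compound 3 can be read. The compounds shown leave open how these structures compare on an exact number, because all of them sit at the same limit: the limit of > 50000 nM in this assay, at which 3 of the 3 values shown sit.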